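Fluoro in place of hydrogen on the shared core

A few compounds are considered here, and "the series" means these few. Any claim that something is new, unique, unknown or untested is made for them only; others in the source may bear on it.

Compound 3 `O=S(=O)(c1ccc(F)cc1)c1cnc2cc(Cl)ccc2c1-c1ccc(Cl)cc1` gives 92.8% in an assay on cell membranes for displacement of a labelled ligand from metabotropic glutamate receptor 5 (Rattus norvegicus), with a stated time of 60 min, tested at 1 uM; on this read-out higher numbers stand for more inhibition at the one concentration tested (going by the name of the read-out) and lower numbers for less inhibition. Compound 1 `O=S(=O)(c1ccc(F)cc1)c1cnc2cc(Cl)c(F)cc2c1-c1ccc(Cl)cc1` gives 48% in this assay; the change between the two is fluoro in place of hydrogen on an aromatic carbon, and the step is a number 44.8 percentage points lower from compound 3 to compound 1 (beyond the scatter). Compound 2 `O=S(=O)(c1ccc(F)cc1)c1cnc2ccc(Cl)cc2c1-c1ccc(Cl)cc1` gives 58.3% in this assay; the difference between its core and that of compound 3 is not broken down here. Compound 4 `O=S(=O)(c1ccc(F)cc1)c1cnc2c(F)cc(Cl)cc2c1-c1ccc(Cl)cc1` carries the same kind of change relative to compound 2, (fluoro in place of hydrogen on an aromatic carbon), but the surroundings differ: in compound 1 the new fluoro is ortho to a chloro group, meta to a fused ring and para to a fused ring, whereas in compound 4 it is ortho to a fused ring, meta to a chloro group and meta to a fused ring. A drop is expected for compound 4, smaller than the measured one because a number 44.8 percentage points lower from compound 3 to compound 1 (beyond the scatter) arose at a different place. The expected step is a number 23.3 percentage points lower from compound 2 to compound 4 (beyond the scatter). Compound 4 is estimated at 35%, between 10% and 60%.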

Compound 4, a percentage reported as inhibition, at one concentration (the size of the read-out at that concentration, not a potency): 19%
For compound 4 the middle estimate is 16 percentage points above the measured one; measured number inside the range.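

In this assay fluoro in place of hydrogen on an aromatic carbon gives a number 39.3 percentage points lower from compound 2 to compound 4 (beyond the scatter), so the change lowers the read-out on both cores, at two different places, and the two steps do not differ: the same change on two cores in this assay, a number 44.8 percentage points lower (beyond the scatter) from compound 3 to compound 1 and a number 39.3 percentage points lower (beyond the scatter) from compound 2 to compound 4, 5.5 percentage points apart, within the scatter of two such steps

On these two pairs, the step carries from one core to the other in direction and in size. Two pairs make no rule for other places on the ring, and percentages at one concentration say nothing about the size of any change in potency.

Still open, going by these compounds, is whether the drop is particular to fluoro or would also follow a methyl group, a methoxy group or a nitrile in place of that hydrogen. Also open, on these data alone, is whether it persists with an amine in place of the chloro group on the core.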